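Trimming the Benzyl Group from Compound 1

The source may hold more compounds than are shown below. What is called first, only, known or untested is meant among the compounds shown, and "the series" means these compounds.

Compound 1 `CC(=O)O[C@@H]1OC(=O)[C@](Cc2ccccc2)(C(C)=O)[C@@H]1C` was tested in a functional assay on B16 cells (Mus musculus) for cytotoxicity, read by MTT assay (a lower number here means a stronger inhibitor, a higher number a weaker inhibitor), where compound 1 gives 41000 nM. Going by the values given here, of the two numbers measured so far, this is the highest, which means the weaker of the two inhibitors. The other measured compound, compound 2 `CC(=O)[C@@]1(C)C(=O)O[C@@H](OC(=O)C(C)(C)C)[C@H]1C`, gives 2000 nM in this assay; it differs from compound 1 in more than one place, so the two values are simply set side by side here, with compound 2 the clearly stronger one.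

Compound 3 `CC(=O)O[C@@H]1OC(=O)[C@@H](C(C)=O)[C@@H]1C` has not yet been measured. It arises from compound 1 by the change (hydrogen in place of benzyl on a saturated ring carbon), that is, hydrogen in place of benzyl on a saturated ring carbon. Among the compounds with values here, no measured pair in this set isolates that change, so its effect in this assay is unknown. Compound 3 is expected to land near compound 1, with a step of a 1.2-fold higher number from compound 1 to compound 3 (0.09 log units; within the scatter) that may well stay within the scatter. The estimate for compound 3 is 50000 nM, with a range from 10000 nM to 200000 nM.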

Compound 3, half-maximal inhibitory concentration: > 50000 nM
Compound 3 gave a limit, no number; the forecaster's own chance of this, stated with the estimate: 25%; the middle value lies on the limit itself.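

In this assay compound 3 gives > 50000 nM, which is a limit of the assay and not a number. Putting hydrogen in place of benzyl on this saturated ring carbon gives an at least 1.2-fold higher number from compound 1 to compound 3 (0.08 log units; that floor lies within the scatter), so the true size of the step cannot be read, and it may be small or much larger. This change brought no stronger inhibition, and what can be said about this position ends at: the limit of > 50000 nM in this assay, at which 1 of the 3 values shown sits.

The compounds shown leave open how an ethyl group, a longer chain or a carboxylic acid on this ring carbon would read in this assay. They also leave open whether an amine placed on the aromatic ring of the benzyl group would move the value of compound 1.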